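The source may hold more compounds than are shown below. What is called first, only, known or untested is meant among the compounds shown, and "the series" means these compounds.

Compound 3 `COc1cc(-c2nn(-c3cccc(NC(=O)Nc4ccc(Cl)c(C(F)(F)F)c4)c3)cc2-c2ccncc2)ccc1Cl` sits second highest of the three numbers in hand in a functional assay on LOX IMVI cells (Homo sapiens) for inhibition, read by sulforhodamine B assay, with a stated time of 48 h; on this read-out lower numbers stand for stronger inhibition of growth and higher numbers for weaker inhibition of growth: compound 3 gives 1170 nM. Its nearest neighbour is compound 2 `O=C(Nc1cccc(-n2cc(-c3ccncc3)c(-c3ccc(Cl)c(O)c3)n2)c1)Nc1ccc(Cl)c(Cl)c1`, which in this assay gives 939 nM, a gap that lies within the scatter; furthest away is compound 1 `O=C(Nc1cccc(-n2cc(-c3ccncc3)c(-c3ccc(Cl)c(O)c3)n2)c1)Nc1cccc(C(F)(F)F)c1`, which gives 2530 nM, a gap beyond the scatter.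

The step to compound 4 `O=C(Nc1cccc(-n2cc(-c3ccncc3)c(-c3ccc(Cl)c(O)c3)n2)c1)Nc1ccc(Cl)c(C(F)(F)F)c1` is hydrogen in place of methyl on an oxygen on an aromatic ring, so that methoxy becomes hydroxy and 4-chloro-3-methoxyphenyl becomes 4-chloro-3-hydroxyphenyl, with the rest of compound 3 kept.

For the measured compounds named here, the single measured step, a 2.7-fold lower number from compound 1 to compound 2 (0.43 log units; beyond the scatter), changes the aryl group on the urea, not the oxygen substituent, so it bears only indirectly on the present change: it shows that the hydroxy-bearing core tolerates variation on the urea aryl with modest movement. Going by the values given here, no measured pair isolates methoxy against hydroxy. Compound 4 carries the hydroxy of compounds 1 and 2 together with the urea aryl of compound 3, whose number falls between those two.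

The step from compound 3 to compound 4 is therefore expected to be small, a 1.2-fold lower number from compound 3 to compound 4 (0.07 log units; within the scatter), and compound 4 is estimated at 1000 nM, within 450 nM to 2300 nM.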

Compound 4, concentration for 50% growth inhibition: 554 nM
The estimate for compound 4 lay 1.8-fold (0.26 log units) above the measured number; the range from low to high includes it.
By their numbers in this assay, from the lowest: compounds 4, 2 and 3 (each within the scatter of the next, the first and the last beyond it); then compound 1.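

Hydrogen in place of methyl on the oxygen gives the first direct reading of methoxy against hydroxy in this assay: there is a 2.1-fold lower number from compound 3 to compound 4 (0.32 log units; beyond the scatter) for this change, a step beyond the scatter, and it holds for the 4-chloro-3-(trifluoromethyl)phenyl urea only. With the hydroxy kept, the urea aryl can now be read against compound 4 as well: chloro in place of hydrogen on an aromatic carbon gives a 4.6-fold lower number from compound 1 to compound 4 (0.66 log units; beyond the scatter) and stands beyond the scatter, whereas trifluoromethyl in place of chloro on an aromatic carbon gives a 1.7-fold lower number from compound 2 to compound 4 (0.23 log units; within the scatter) and stays within it, so these two urea aryl groups are not separated here. No measurement at hand accounts for any of these steps.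

From the compounds shown here alone, whether methoxy to hydroxy moves the number in the same direction on the 3-(trifluoromethyl)phenyl or 3,4-dichlorophenyl urea remains open. Also open, going by these compounds, is how an ethoxy group or an amine on that same aromatic carbon would compare with the hydroxy of compound 4.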